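The source may hold more compounds than are shown below. What is called first, only, known or untested is meant among the compounds shown, and "the series" means these compounds.

Three compounds of the series have so far been run in a functional assay on MCF7 cells (Homo sapiens) for inhibition, read by MTT assay, with a stated time of 24 h; on this read-out lower numbers stand for stronger inhibition and higher numbers for weaker inhibition. Compound 1 `CCOC(=O)C1=Cc2ccccc2OC1(OCc1cn(CC(=O)Nc2ccccc2Br)nn1)C(F)(F)F` carries a 2-bromophenyl on an amide-type nitrogen. In this assay compound 1 reaches only the limit, > 150000 nM. Compound 2 `CCOC(=O)C1=Cc2ccccc2OC1(OCc1cn(CC(=O)Nc2ccc(C)cc2)nn1)C(F)(F)F` differs from it by a 4-methylphenyl in place of the 2-bromophenyl on that nitrogen. In this assay compound 2 likewise reaches only the limit, > 150000 nM. Between them the step is a step that the two limits leave unreadable from compound 1 to compound 2. Compound 3 `CCOC(=O)C1=Cc2ccccc2OC1(OCc1cc(-c2ccc(Br)cc2)no1)C(F)(F)F` completes the measured set. In this assay compound 3 also reaches only the limit, > 150000 nM. Where compound 2 stands is thus fixed by a limit alone, and the same holds for the two other values, so that the limit of > 150000 nM in this assay, at which 3 of the 3 values shown sit, is the whole of the evidence the measured compounds give.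

Compound 4 `CCOC(=O)C1=Cc2ccccc2OC1(OCc1cn(-c2ccc(F)c([N+](=O)[O-])c2)nn1)C(F)(F)F` has not yet been measured. Against compound 2 the change is 4-fluoro-3-nitrophenyl in place of ((4-methylphenyl)carbamoyl)methyl on an aromatic nitrogen. For the measured compounds named here, no measured step bears on an exchange of this kind; the single measured step is unreadable, and every value sits at the limit. The expectation for compound 4 in this assay is therefore a value at or beyond the same limit, an expected step that the limit leaves unreadable from compound 2 to compound 4. Compound 4 is accordingly estimated at 200000 nM, within 100000 nM to 1000000 nM.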

Compound 4, half-maximal inhibitory concentration: 16200 nM
The estimate for compound 4 lay 12-fold (1.09 log units) above the measured number; the whole stated range lies above it.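

In this assay, for the compounds shown here, the substituent on the aromatic nitrogen of the five-membered aromatic ring with 3 nitrogen is the first place where the read-out comes off the limit: 4-fluoro-3-nitrophenyl in place of ((4-methylphenyl)carbamoyl)methyl gives an at least 9.2-fold lower number from compound 2 to compound 4 (0.96 log units; beyond the scatter), and in place of ((2-bromophenyl)carbamoyl)methyl it gives an at least 9.2-fold lower number from compound 1 to compound 4 (0.96 log units; beyond the scatter). Both steps lie beyond the scatter, but each starts from a limit and is therefore only a bound on the true size, while the steps among the compounds at the limit cannot be read. Compound 4 alone carries a number, and the other compounds remain at a limit: the limit of > 150000 nM in this assay, at which 3 of the 4 values shown sit.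

The exchange replaces the whole substituent at once, so the compounds shown do not separate the loss of the carbamoylmethyl chain and the amide hydrogen from the entry of the fluorine and the nitro group. A plain phenyl, a 4-fluorophenyl or a 3-nitrophenyl on that nitrogen, or an amine in place of the nitro group, would show which part of 4-fluoro-3-nitrophenyl the step depends on.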